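Taking the trifluoromethyl away from compound 2

The source may hold more compounds than are shown below. What is called first, only, known or untested is meant among the compounds shown, and "the series" means these compounds.

Compound 1 `O=[N+]([O-])c1ccc(/N=N/N2CCCC2)cc1`: >= 100000 nM
Compound 2 `FC(F)(F)c1cccc(/N=N/N2CCCC2)c1`: > 100000 nM

Both compounds were tested in an ADME assay on MT4 cells (Homo sapiens) for cytotoxicity, read by MTT assay, with a stated time of 96 h; on this read-out higher numbers stand for lower toxicity in this test and lower numbers for higher toxicity in this test. Compound 2 gives > 100000 nM, which is a limit of the assay and not a number. Compound 1 gives >= 100000 nM, and this is also a limit. Neither compound has an exact value, so the two cannot be ranked.

The next compound is compound 3 `c1ccc(/N=N/N2CCCC2)cc1`. It has hydrogen in place of trifluoromethyl on an aromatic carbon of compound 2: hydrogen in place of trifluoromethyl on an aromatic carbon. Going by the values given here, no measured pair shows what a change like this does. The expected step of a number no higher from compound 2 to compound 3 (the limit leaves the size open) in this assay is none beyond the usual scatter, and any real shift is expected to go toward lower numbers. Compound 3 is estimated at 100000 nM, with an expected range from 40000 nM to 100000 nM.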

Compound 3, half-maximal cytotoxic concentration: > 100000 nM
Compound 3 was reported as a limit; the forecaster's own chance of this, stated with the estimate: 70%; the middle value lies on the limit itself.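

Going by these compounds alone, compound 3, like compound 1 and compound 2, gives only a limit and not a number in this assay, so no step from either of them to compound 3 can be read. The compounds shown leave open whether trifluoromethyl, nitro or hydrogen on the aromatic carbon makes any difference to toxicity in this test.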